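Phenyl in place of pyridin-2-yl on compound 1

This account rests on a few compounds, and the source may have more. Where it says the series, first, only, none or still open, it means among the compounds named here.

In a physicochemical assay for solubility, in simulated intestinal fluid, at pH 7.4 (a lower number here means a less soluble compound, a higher number a more soluble compound), compound 1 (`Cn1cc(C(=O)Nc2ccc(-c3ccccn3)c(C(F)(F)F)c2)c(=O)c2cnccc21`) gives 6.7 ug/mL and compound 2 (`Cn1cc(C(=O)Nc2ccc(-c3ccccc3)c(C(F)(F)F)c2)c(=O)c2cccnc21`) gives 5.9 ug/mL as its reading. Within the data shown here, these two values lie within the scatter of each other, so compound 1 stands level with the only other measured compound.

Compound 3 (`Cn1cc(C(=O)Nc2ccc(-c3ccccc3)c(C(F)(F)F)c2)c(=O)c2cnccc21`) is still unmeasured. It has phenyl in place of pyridin-2-yl on an aromatic carbon and keeps the rest of compound 1 unchanged.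

Among the measured compounds shown here, no measured pair isolates this change, so the data give no direct size for it. Compound 2 also carries phenyl, and at 5.9 ug/mL it offers no sign of a large step. A small step toward a lower number in this assay is expected, probably not beyond the scatter. The estimated step is a 1.5-fold lower number from compound 1 to compound 3 (0.17 log units; within the scatter) on these grounds. For compound 3 the expected value is 4.5 ug/mL with an estimated range from 1.8 ug/mL to 10 ug/mL as working bounds.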

Compound 3, solubility: 4.9 ug/mL
Compound 3: middle estimate off by 1.1-fold (0.04 log units), on the low side; the range from low to high includes it.
By their numbers in this assay, from the lowest: compounds 3, 2 and 1 (each within the scatter of the next).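

Phenyl in place of pyridin-2-yl, on an aromatic carbon ortho to a trifluoromethyl group, now has a direct reading in this assay: this single change gives a 1.4-fold lower number from compound 1 to compound 3 (0.14 log units; within the scatter). At this position, the hydrogen-bond acceptor counted on pyridin-2-yl can therefore be lost, with the rest of compound 1 unchanged, without a step beyond the scatter. Nothing at hand explains the size of this step.

Among these compounds, the comparison covers only two six-membered aromatic rings, so it remains open whether a group of another kind at this position, such as morpholine or a carboxylic acid, would give a step beyond the scatter. Also open, from the compounds shown here alone, is whether the same exchange gives a similar step on the core of compound 2.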